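Compound 4: a step from compound 1

The source may hold more compounds than are shown below. What is called first, only, known or untested is meant among the compounds shown, and "the series" means these compounds.

Measured so far in an ADME assay on MDCKII-LE cells (Canis lupus familiaris) for permeability; on this read-out lower numbers stand for lower permeability and higher numbers for higher permeability:
- compound 1 `N#CC12CC(CN([C@H](CCC(F)(F)F)C(N)=O)S(=O)(=O)c3ccc(Cl)cc3)(C1)C2` gives 30.2 10^-6 cm/s
- compound 2 `N#Cc1ccc(CN([C@H](CCC(F)(F)F)C(N)=O)S(=O)(=O)c2ccc(Cl)cc2)cc1` gives 19.7 10^-6 cm/s
- compound 3 `N#C[C@@H]1C[C@H]1CN([C@H](CCC(F)(F)F)C(N)=O)S(=O)(=O)c1ccc(Cl)cc1` gives 9.94 10^-6 cm/s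

Compound 1 stands level with compound 2 within the scatter and clear of compound 3. Compound 4 `N#C[C@H]1C[C@H](CN([C@H](CCC(F)(F)F)C(N)=O)S(=O)(=O)c2ccc(Cl)cc2)C1` changes compound 1 as follows: a group of 6 heavy atoms (5 carbon, 1 nitrogen; one four-membered non-aromatic ring of carbon only) in place of a group of 7 heavy atoms (6 carbon, 1 nitrogen; 2 four-membered non-aromatic rings of carbon only), on a saturated chain carbon bound to a sulfonamide nitrogen. Measured swaps at that same place give the guide: a 1.5-fold lower number from compound 1 to compound 2 (0.19 log units; within the scatter) and a 3.0-fold lower number from compound 1 to compound 3 (0.48 log units; beyond the scatter). Among the measured compounds shown here, no measured compound carries 3-cyanocyclobutyl, so the reading is indirect. A lower number is expected in this assay, with a step smaller than a 3.0-fold lower number from compound 1 to compound 3 (0.48 log units; beyond the scatter) and possibly within the scatter. The estimated step is a 1.7-fold lower number from compound 1 to compound 4 (0.22 log units; within the scatter) by this expectation. Compound 4 is estimated at 18 10^-6 cm/s (expected range 9 10^-6 cm/s to 34 10^-6 cm/s).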

Compound 4, apparent permeability: 24.9 10^-6 cm/s
Compound 4: middle estimate off by 1.4-fold (0.14 log units), on the low side; the measured number falls inside the stated range.
By their numbers in this assay, from the lowest: compounds 3, 2, 4 and 1 (each within the scatter of the next, the first and the last beyond it).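

In this assay, 3-cyanocyclobutyl on this saturated chain carbon stands level with the two-ring group of compound 1 (a 1.2-fold lower number from compound 1 to compound 4 (0.08 log units; within the scatter)) and with the 4-cyanophenyl of compound 2 (a 1.3-fold higher number from compound 2 to compound 4 (0.10 log units; within the scatter)). It stands clear of 2-cyanocyclopropyl (a 2.5-fold higher number from compound 3 to compound 4 (0.40 log units; beyond the scatter)), so removing one four-membered ring from the group of compound 1 changes little, while the three-membered ring of compound 3 gives a modest drop. No measurement shown gives a reason for this. Going by these compounds, all four compounds carry a nitrile, so what an amine or a carboxylic acid would do in its place stays open.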